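The source may report more compounds than this note shows. Statements on the series, on what has been measured and on what is new or still open speak of the compounds shown alone.

Measured compounds:
compound 1 `Cc1ccc2[nH]c(-c3c(-c4ccc(F)cc4)nc4sc(C)nn34)nc2c1`, 11700 nM
compound 2 `Cc1ccc(-c2nc3sc(C)nn3c2-c2nc3cc(C)ccc3[nH]2)cc1`, 9800 nM
compound 3 `Cc1ccc(-c2nc3sc(C)nn3c2-c2nc3c(C)c(C)ccc3[nH]2)cc1`, 10300 nM

All three were tested in a functional assay on A549 cells (Homo sapiens) for antiproliferative activity, read by MTT assay; on this read-out lower numbers stand for stronger inhibition and higher numbers for weaker inhibition. Compound 1 and compound 2 differ in their cores by fluoro in place of methyl on an aromatic carbon, and the step of a 1.2-fold lower number from compound 1 to compound 2 (0.08 log units; within the scatter) is small. Compound 3 differs from compound 2 by methyl in place of hydrogen on an aromatic carbon, a change that made the step of a 1.1-fold higher number from compound 2 to compound 3 (0.02 log units; within the scatter). Compound 4 `Cc1nn2c(-c3nc4cc(C)c(C)cc4[nH]3)c(-c3ccc(F)cc3)nc2s1` is not yet measured; it differs from compound 1 by methyl in place of hydrogen on an aromatic carbon. The two places are not identical: in compound 3 the methyl sits ortho to a fused ring, ortho to a methyl group and meta to a fused ring, whereas in compound 4 it sits ortho to a methyl group, meta to a fused ring and para to a fused ring, so this is the same kind of change rather than the same one. Resting on the step of compound 3, a 1.1-fold higher number from compound 2 to compound 3 (0.02 log units; within the scatter), the account expects a step of a 1.0-fold higher number from compound 1 to compound 4 (0.01 log units; within the scatter) for compound 4. Compound 4 is therefore estimated at 12000 nM, expected between 6000 nM and 25000 nM.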

Compound 4, half-maximal inhibitory concentration: > 30000 nM
Compound 4 gave a limit, no number; the forecaster's own chance of this, stated with the estimate: 12%; at least 2.5-fold (0.39 log units) between middle value and limit.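

In this assay compound 4 gave > 30000 nM, which is a limit of the assay and not a number. The methyl in place of hydrogen produced an at least 2.5-fold higher number from compound 1 to compound 4 (0.40 log units; beyond the scatter), so on this core the change shows a step beyond the scatter, and a step within the scatter on one core did not foretell it here. This does not show that the two steps truly differ in size, and two cores give no rule for the series: the same change on two cores in this assay, a 1.1-fold higher number (0.02 log units; within the scatter) from compound 2 to compound 3 and an at least 2.5-fold higher number (0.40 log units; beyond the scatter) from compound 1 to compound 4; the limit leaves it open whether they differ

Going by these compounds, how an amine or a methoxy group in place of this methyl would read in this assay remains open. So does whether a chloro group in place of the fluoro would alter the step.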